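Swapping the Methyl Pattern on the Amide-Side Phenyl

The compounds below may be only part of what the source reports. "The series", "measured", "known", "first", "only" and "open" are said of these compounds alone.

Compound 1, `O=C(Nc1ccccc1)c1ccc(/N=N\c2c[nH]c3ccccc23)cc1`, gives 103000 nM in a functional assay on HCT-116 cells (Homo sapiens) for inhibition, read by MTT assay, with a stated time of 72 h; on this read-out lower numbers stand for stronger inhibition and higher numbers for weaker inhibition.
Compound 2, `Cc1ccc(NC(=O)c2ccc(/N=N\c3c[nH]c4ccccc34)cc2)cc1`, gives 25400 nM in this assay.
Compound 3, `Cc1cccc(NC(=O)c2ccc(/N=N\c3c[nH]c4ccccc34)cc2)c1C`, gives 272000 nM in this assay.

Among these three, compound 3 has the highest number, and both of its steps to the others lie beyond the scatter, so it is the weakest inhibitor shown. Compound 4 is `Cc1ccc(NC(=O)c2ccc(/N=N\c3c[nH]c4ccccc34)cc2)c(C)c1`; it differs from compound 3 in one place: 2,4-dimethylphenyl in place of 2,3-dimethylphenyl on an amide-type nitrogen.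

Going by the values given here, two measured steps bear on this change. Adding a methyl to the plain phenyl of compound 1 gave a 4.1-fold lower number from compound 1 to compound 2 (0.61 log units; beyond the scatter), and going from the 4-methylphenyl of compound 2 to the 2,3-dimethylphenyl of compound 3 gave an 11-fold higher number from compound 2 to compound 3 (1.03 log units; beyond the scatter). The dimethyl pattern of compound 4 combines the group that helped in compound 2 with a second methyl, for which no direct comparison exists. The expectation is therefore a number somewhat lower than that of compound 3 in this assay, though not as low as that of compound 2, with wide uncertainty. For compound 4 the estimate is 70000 nM, within 20000 nM to 250000 nM, corresponding to an expected step of a 3.9-fold lower number from compound 3 to compound 4 (0.59 log units; beyond the scatter).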

Compound 4, half-maximal inhibitory concentration: 76100 nM
Estimate against measurement, compound 4: 1.1-fold (0.04 log units) below; the measured number falls inside the stated range.
By their numbers in this assay, from the lowest: compound 2; then compounds 4 and 1 (each within the scatter of the next); then compound 3.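

Moving a single methyl, with the same atoms in the molecule, is enough to shift the result in this assay: 2,4-dimethylphenyl in place of 2,3-dimethylphenyl on the amide-type nitrogen gives a 3.6-fold lower number from compound 3 to compound 4 (0.55 log units; beyond the scatter), so where the methyls sit on this ring matters, not only how many there are. Adding a methyl to the 4-methylphenyl group of compound 2 to reach the 2,4-dimethylphenyl group weakens inhibition, with a 3.0-fold higher number from compound 2 to compound 4 (0.48 log units; beyond the scatter), and against the plain phenyl the comparison gives a 1.4-fold lower number from compound 1 to compound 4 (0.13 log units; within the scatter), so these two groups cannot be told apart in this measurement. Nothing available explains why the placement of the methyls changes the result.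

The compounds shown carry only methyl groups on this ring, so how a methoxy, a chlorine or an amine in their place would read in this assay stays open. As far as these compounds go, with a single cell line and a single read-out, it also stays open whether the same order of compounds would hold in other cells.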